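Swapping the thiophene for cyclopropyl on the shared core

The compounds below may be only part of what the source reports. "The series", "measured", "known", "first", "only" and "open" are said of these compounds alone.

Among the compounds with values here, compound 1 `CCOC(=O)c1cnc(-c2cccs2)nc1NN1C(=O)C=C(C)C1=O` stands lowest of the two numbers measured so far: in a functional assay on Jurkat cells for inhibition of nuclear factor NF-kappa-B complex (Homo sapiens) (on this read-out higher numbers stand for weaker inhibition and lower numbers for stronger inhibition), compound 1 gives 20 nM. Within the data shown here, its nearest neighbour is compound 2 `CCOC(=O)c1cnc(-c2ccc(OC)cc2)nc1NN1C(=O)C=C(C)C1=O`, which in this assay gives 900 nM; the single change of 4-methoxyphenyl in place of thiophen-2-yl on an aromatic carbon produced a 45-fold higher number from compound 1 to compound 2 (1.65 log units; beyond the scatter). Compound 3 `CCOC(=O)c1cnc(C2CC2)nc1NN1C(=O)C=C(C)C1=O` has not yet been measured. It differs from compound 1 by cyclopropyl in place of thiophen-2-yl on an aromatic carbon. Among the measured compounds shown here, only one measured step bears on this change, and it shows that replacing the thiophen-2-yl group at this aromatic carbon can cost a great deal. A cyclopropyl group is a different replacement, so the size cannot be read directly from that step, but compound 3 is expected to fall on the weaker side of compound 1, with a step of a 30-fold higher number from compound 1 to compound 3 (1.48 log units; beyond the scatter) because of a 45-fold higher number from compound 1 to compound 2 (1.65 log units; beyond the scatter). Compound 3 is therefore estimated at 600 nM, in the range 100 nM to 4000 nM.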

Compound 3, half-maximal inhibitory concentration: 1000 nM
Compound 3: middle estimate off by 1.7-fold (0.22 log units), on the low side; the measured number falls inside the stated range.
By their numbers in this assay, from the lowest: compound 1; then compounds 2 and 3 (each within the scatter of the next).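

In this assay, the loss on leaving thiophen-2-yl is not peculiar to 4-methoxyphenyl: cyclopropyl, a three-membered non-aromatic ring of carbon only, brings a 50-fold higher number from compound 1 to compound 3 (1.70 log units; beyond the scatter) and so also lands far from compound 1. The two replacements themselves cannot be told apart, with a 1.1-fold higher number from compound 2 to compound 3 (0.05 log units; within the scatter), so at this carbon between two ring nitrogen atoms, only thiophen-2-yl stands apart among the three groups shown. Nothing available explains why this group stands apart.

The compounds shown leave open whether the low number belongs to thiophen-2-yl alone or extends to other five-membered aromatic rings, such as furan-2-yl or thiophen-3-yl. They also leave open how an unsubstituted phenyl or a small amine at this carbon would read out.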